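Oxime ether in place of oxazole on the shared core

The compounds below may be only part of what the source reports. "The series", "measured", "known", "first", "only" and "open" are said of these compounds alone.

Measured compounds:
compound 1 `c1ccc(-c2cnoc2)c(NCC2=NCCN2)c1` with < 100000 nM
compound 2 `Nc1nccc(-c2ccccc2NCC2=NCCN2)n1` with 28.8 nM

In a functional assay for activation of Alpha-1D adrenergic receptor (Homo sapiens) (a lower number here means that less compound is needed, a higher number that more compound is needed for the effect), compound 1 gives only a limit, < 100000 nM, so no number is known for it; the evidence on it is the limit of < 100000 nM in this assay, at which 1 of the 2 values shown sits. In this assay compound 2 gives 28.8 nM, a number. The two results cannot be compared as a step; one of them is not a number.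

Compound 3 `CC/C(=N\OC)c1ccccc1NCC1=NCCN1` has not yet been measured. It differs from compound 1 in one place: a group of 6 heavy atoms (4 carbon, 1 nitrogen, 1 oxygen; no ring) in place of a group of 5 heavy atoms (3 carbon, 1 nitrogen, 1 oxygen; one five-membered aromatic ring with 2 hetero atoms), on an aromatic carbon

Going by the values given here, no step between measured compounds is known here, so the size of the change from compound 1 to compound 3 in this assay cannot be read from a matched pair. Going by these compounds, because compound 1 sits at the limit of < 100000 nM in this assay, at which 1 of the 2 values shown sits, any direction of the step remains open: compound 3 could fall at the limit again or give a number. The expected outcome is a step that the limit leaves unreadable from compound 1 to compound 3, with a real chance that only a limit is reported again.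

For compound 3 the estimate in this assay is 5000 nM, expected to fall between 300 nM and 80000 nM.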

Compound 3, half-maximal effective concentration: < 100000 nM
Compound 3: no number, only a limit; the forecaster's own chance of this, stated with the estimate: 35%; the middle value does not contradict the limit.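

In this assay, compound 1 and compound 3 both give only a limit, so no step can be read between them: the limit of < 100000 nM in this assay, at which 2 of the 3 values shown sit.

The compounds shown leave open whether the 1,2-oxazol-4-yl group of compound 1 and the ring-free group of compound 3 differ at all in this assay.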